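Dropping the Methyl from the Chloro Analogue

The compounds below may be only part of what the source reports. "The series", "measured", "known", "first", "only" and "open" are said of these compounds alone.

Compound 1 `Cc1cnc2nc(-c3ccc(F)cc3)cc(O)c2c1`: 2630 nM
Compound 2 `Cc1cnc2nc(-c3ccc(Cl)cc3)cc(O)c2c1`: 603 nM
Compound 3 `COc1cccc(-c2cc(O)c3cc(C)cnc3n2)c1`: < 10 nM

In a functional assay on MDA-MB-435 cells (Homo sapiens) (on this read-out lower numbers stand for stronger inhibition of growth and higher numbers for weaker inhibition of growth), compound 2 gives 603 nM, the lowest of the two numbers shown. Within the data shown here, compound 1 gives 2630 nM, and the only measured step, a 4.4-fold lower number from compound 1 to compound 2 (0.64 log units; beyond the scatter), is a swap of chloro for fluoro. Compound 3 reaches a limit of the assay, < 10 nM. One of the three values sits at the limit of < 10 nM in this assay, at which 1 of the 3 values shown sits.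

Compound 4 `Oc1cc(-c2ccc(Cl)cc2)nc2ncccc12` differs from compound 2 by hydrogen in place of methyl on an aromatic carbon. Among the measured compounds shown here, no measured step touches the methyl, so the one known step offers no guide. The change is therefore expected to give a 1.7-fold higher number from compound 2 to compound 4 (0.22 log units; within the scatter), nothing beyond the scatter. Compound 4 is estimated at 1000 nM, with a range from 300 nM to 3500 nM.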

Compound 4, concentration for 50% growth inhibition: 5890 nM
The estimate for compound 4 lay 5.9-fold (0.77 log units) below the measured number; measured number outside the range, above it.
By their numbers in this assay, from the lowest: compound 2; then compound 1; then compound 4. At a limit, below all of these: compound 3.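

In this assay, the methyl on this aromatic carbon, two atoms from the ring nitrogen, proves to matter: hydrogen in its place gives a 9.8-fold higher number from compound 2 to compound 4 (0.99 log units; beyond the scatter). Among these compounds, the earlier compounds showed a change only at the halogen, so this is the first measured sign that a group on the shared core also moves the number, though it is read with chloro in place only. Nothing shown here accounts for the step. From the compounds shown here alone, whether an ethyl group or an amine on this carbon would keep the number of compound 2 stays open. So does whether the methyl counts as much in the series of compound 3.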